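The source may hold more compounds than are shown below. What is called first, only, known or untested is meant among the compounds shown, and "the series" means these compounds.

The measured compounds and their numbers:

Compound 1 `COc1ccc(C2N=C(SCc3cccc(Cl)c3)NC(C)=C2C(=O)Nc2ccc(F)cc2)cc1OC` gives 20.1% in a functional assay on the whole organism (artery, strain albino) with Rattus norvegicus as the target, with a stated time of 360 min, at a dose of 10 mg/kg by the oral route; on this read-out higher numbers stand for more inhibition at the one dose given (going by the name of the read-out) and lower numbers for less inhibition.
Compound 2 `COc1ccc(C2N=C(SCc3ccc(Cl)cc3)NC(C)=C2C(=O)Nc2ccc(F)cc2)cc1OC` gives 37.1% in this assay.
Compound 3 `CC1=C(C(=O)Nc2ccc(F)cc2)C(c2ccc([N+](=O)[O-])cc2)N=C(SCc2cccc(Cl)c2)N1` gives 21.1% in this assay.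

Compound 3 differs from compound 1 by 4-nitrophenyl in place of 3,4-dimethoxyphenyl on a saturated ring carbon, and this gives a number 1 percentage points higher from compound 1 to compound 3 (within the scatter). Compound 2 differs from compound 1 by 4-chlorophenyl in place of 3-chlorophenyl on a saturated chain carbon bound to a sulfur, which gives a number 17 percentage points higher from compound 1 to compound 2 (beyond the scatter). Compound 4 `CC1=C(C(=O)Nc2ccc(F)cc2)C(c2ccc([N+](=O)[O-])cc2)N=C(SCc2ccc(Cl)cc2)N1` is not yet measured; it differs from compound 3 by 4-chlorophenyl in place of 3-chlorophenyl on a saturated chain carbon bound to a sulfur, the same change at the same place, made on the core of compound 3 instead of the core of compound 1. Since compound 1 and compound 3 sit close together in this assay, the step is expected to be similar, giving an expected a number 13.9 percentage points higher from compound 3 to compound 4 (beyond the scatter). Compound 4 is therefore estimated at 35%, between 20% and 50%.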

Compound 4, a percentage reported as inhibition, in the whole organism at one dose (the size of the read-out at that dose, not a potency): 39.7%
Compound 4: the middle estimate sits 4.7 percentage points below what was measured, within the range that was stated.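

In this assay, 4-chlorophenyl in place of 3-chlorophenyl gives a number 18.6 percentage points higher from compound 3 to compound 4 (beyond the scatter), and this step carries over from one core to the other at about the same size: the same change on two cores in this assay, a number 17 percentage points higher (beyond the scatter) from compound 1 to compound 2 and a number 18.6 percentage points higher (beyond the scatter) from compound 3 to compound 4, 1.6 percentage points apart, within the scatter of two such steps. Replacing 3,4-dimethoxyphenyl with 4-nitrophenyl gives a number 2.6 percentage points higher from compound 2 to compound 4 (within the scatter), and this small step also holds whichever chlorophenyl is present: the same change on two cores in this assay, a number 1 percentage points higher (within the scatter) from compound 1 to compound 3 and a number 2.6 percentage points higher (within the scatter) from compound 2 to compound 4, 1.6 percentage points apart, within the scatter of two such steps. Within the data shown here, the two changes therefore appear to add up independently across these four compounds, but this rests on only two cores at a single dose and does not show why the step arises or that it would hold on any other core.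

On these data alone, the effect of a plain benzyl or a longer alkyl chain on the sulfur remains open. So does the effect of an amine or a carboxylic acid on the phenyl group at the saturated ring carbon.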